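From ethoxycarbonyl to hydroxymethyl: compound 2 to compound 3

This account rests on a few compounds, and the source may have more. Where it says the series, first, only, none or still open, it means among the compounds named here.

Compound 1 `COc1cc([C@@H]2C[C@@]2(CO)C(=O)Nc2ccccc2)cc(OC)c1OC`: > 100000 nM
Compound 2 `CCOC(=O)[C@@]1(C(=O)Nc2ccccc2)C[C@@H]1c1cc(OC)c(OC)c(OC)c1`: > 100000 nM
Compound 3 `COc1cc([C@H]2C[C@@]2(CO)C(=O)Nc2ccccc2)cc(OC)c1OC`: not yet measured

Both measurements come from a functional assay on K562 cells (Homo sapiens) for cytotoxicity, read by MTT assay, with a stated time of 48 h; on this read-out lower numbers stand for stronger inhibition and higher numbers for weaker inhibition. Compound 2 gives > 100000 nM, which is a limit of the assay and not a number. Compound 1 gives > 100000 nM, which is also a limit. The whole measured set therefore stands at one place: the limit of > 100000 nM in this assay, at which 2 of the 2 values shown sit.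

The move to compound 3 changes one group, with hydroxymethyl in place of ethoxycarbonyl on a saturated ring carbon. Among the measured compounds shown here, no measured step shows how large such a change can be, so the expectation has only a weak basis. In this assay, no large step is expected, and any gain in strength should be modest. The expected change is an at least 1.1-fold lower number from compound 2 to compound 3 (0.04 log units; that floor lies within the scatter), which is small. Compound 3 will most likely also return a limit rather than a number. As a number, compound 3 is estimated at 90000 nM, with an expected range from 30000 nM to 200000 nM.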

Compound 3, half-maximal inhibitory concentration: > 100000 nM
Compound 3 gave a limit, no number (the forecaster's own chance of this, stated with the estimate: 70%); at least 1.1-fold (0.04 log units) between middle value and limit.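

Among the compounds shown here, compounds 1, 2 and 3 all end at a limit, so neither the step from compound 2 to compound 3 nor the one from compound 1 to compound 3 can be read: the limit of > 100000 nM in this assay, at which 3 of the 3 values shown sit. Left open is whether hydroxymethyl in place of ethoxycarbonyl, or the configuration as drawn at the saturated ring carbon, changes the result in this assay at all.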